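Azido for sulfanyl on the shared core

The source may hold more compounds than are shown below. What is called first, only, known or untested is meant among the compounds shown, and "the series" means these compounds.

Compound 1 `Sc1[nH]ccc2ncnc1-2` is the higher of the two compounds measured in a functional assay (Homo sapiens) for inhibition of Nucleic Acid, tested at 100 uM; on this read-out lower numbers stand for less inhibition and higher numbers for more inhibition at the one concentration tested (going by the name of the read-out): compound 1 gives 26%, while compound 2 `OC[C@H]1OC(n2cnc3c(S)nccc32)[C@H](O)[C@@H]1O` in this assay gives 6%, a gap beyond the usual scatter. Compound 3 `[N-]=[N+]=Nc1[nH]ccc2ncnc1-2` carries the change azido in place of sulfanyl on an aromatic carbon relative to compound 1. Among the compounds with values here, no measured pair shows this change, so the size of the step is open; a small downward step, or none beyond the scatter, is expected, a number 6 percentage points lower from compound 1 to compound 3 (within the scatter). Compound 3 is expected to give 20% in this assay, in the range 5% to 40%.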

Compound 3, a percentage reported as inhibition, at one concentration (the size of the read-out at that concentration, not a potency): 20%
For compound 3 middle estimate and measured number coincide at the digits printed; the range from low to high includes it.
By their numbers in this assay, from the lowest: compound 2; then compounds 3 and 1 (each within the scatter of the next).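

In this assay, azido in place of sulfanyl on an aromatic carbon next to the ring nitrogen reads as a number 6 percentage points lower from compound 1 to compound 3 (within the scatter) on the shared core. Sulfanyl is therefore not required at this position for a reading of this size, at least with this one replacement. Nothing available explains how the two groups compare.

From the compounds shown here alone, whether an amine or a hydroxyl group at this position would stay within the scatter of compound 1 remains open. Also open, going by these compounds, is whether a longer chain, such as methylthio or ethylthio, would be accepted here.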